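From Methoxyphenyl to Dichlorophenyl on the Ring Amine

This account rests on a few compounds, and the source may have more. Where it says the series, first, only, none or still open, it means among the compounds named here.

Compound 1, `COc1ccc(/C=C2\NC(=O)N(CCCN3CCN(c4ccccc4OC)CC3)C2=O)cc1OC` — in an assay on CHO cells for displacement of a labelled ligand from 5-hydroxytryptamine receptor 7 (Homo sapiens), read by scintillation counting, with a stated time of 60 min (on this read-out higher numbers stand for weaker inhibition and lower numbers for stronger inhibition), compound 1 gives 42 nM.
Compound 2, `COc1ccc(/C=C2\NC(=O)N(CCCCN3CCN(c4ccccc4OC)CC3)C2=O)cc1OC` — in this assay compound 2 gives 16 nM.

Of the two compounds measured, compound 2 carries the lower number, and the gap to compound 1 lies beyond the usual scatter of this kind of measurement, so compound 2 stands as the stronger binder of the pair. The two share the same core and the same terminal aryl group; they differ only in the length of the chain that joins the core to the ring amine.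

Compound 3, `COc1ccc(/C=C2\NC(=O)N(CCCCN3CCN(c4cccc(Cl)c4Cl)CC3)C2=O)cc1OC`, keeps the longer chain of compound 2 and alters the aryl group instead: 2,3-dichlorophenyl in place of 2-methoxyphenyl on an amine nitrogen in a ring. Among the compounds with values here, no pair of measured compounds in this set shows what such an exchange does, so the expectation rests on compound 2 alone. The step is expected to be a 1.9-fold higher number from compound 2 to compound 3 (0.27 log units; within the scatter), a modest move toward a higher number, or none beyond the scatter. In this assay compound 3 is therefore estimated at 30 nM, with a likely range from 8 nM to 120 nM.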

Compound 3, inhibition constant: 0.8 nM
Estimate against measurement, compound 3: 38-fold (1.57 log units) above; measured number below the stated range.
By their numbers in this assay, from the lowest: compound 3; then compound 2; then compound 1.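

In this assay, placing 2,3-dichlorophenyl where 2-methoxyphenyl stood on the amine nitrogen in the ring gives a 20-fold lower number from compound 2 to compound 3 (1.30 log units; beyond the scatter) and takes the series into a new range of numbers. Within the data shown here, this is the first reading at this position, since the earlier pair differed only in chain length, and the printed values of that pair, with compound 1 at 42 nM and compound 2 at 16 nM, lie much closer together than those across the aryl exchange. The two aryl groups have the same count of heavy atoms and the same six-membered aromatic ring of carbon, differing in that the one leaving has a hydrogen-bond acceptor and the one entering has none, but nothing measured here explains why the number falls so far.

The compounds shown leave open whether 2,3-dichlorophenyl gives a step of similar size on the shorter chain of compound 1 or on a longer chain. They also leave open whether both chlorines are needed for this step, as a phenyl ring with a single chlorine or a plain phenyl ring on the same ring amine would show.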